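Working notes: microsomal stability across two amine substituents

The compounds below may be only part of what the source reports. "The series", "measured", "known", "first", "only" and "open" are said of these compounds alone.

Measured so far:
- compound 1 `CN(Cc1ccccc1)c1cc(=O)c2cc(C(F)(F)F)cc([N+](=O)[O-])c2s1`: 13%
- compound 2 `O=c1cc(N2CCN(CC3CCCCC3)CC2)sc2c([N+](=O)[O-])cc(C(F)(F)F)cc12`: 61.5%

Two compounds on the shared core have been run in an ADME assay on microsomes from liver (Mus musculus, strain CD-1) for metabolic stability, read by LC-MS, using NADPH, with a stated time of 30 min, tested at 1 uM; a higher number here means that more of the compound is left, a lower number that less of the compound is left. In this assay compound 1 gives 13%, while compound 2 gives 61.5%. Compound 2 therefore stands highest of the two numbers, and its nearest neighbour, compound 1, lies well beyond the scatter below it. Within the data shown here, no stepwise pair of measured compounds differing in one place is available, so the gap between compound 1 and compound 2 is simply what the two values show.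

The next compound, compound 3 `CC1CN(c2cc(=O)c3cc(C(F)(F)F)cc([N+](=O)[O-])c3s2)CCN1CC1CCCCC1`, keeps the core and the cyclohexylmethyl-bearing ring of compound 2 and differs from it only as follows: methyl in place of hydrogen on a saturated ring carbon. Among the measured compounds shown here, nothing measured so far speaks to a change of this kind, so the expectation rests on compound 2 alone. The step from compound 2 to compound 3 in this assay is expected to be small, likely none beyond the scatter, a number 5.5 percentage points lower from compound 2 to compound 3 (within the scatter). For compound 3 the expected result in this assay is 56%, with a range from 35% to 76%.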

Compound 3, percent of the compound remaining: 59.9%
The estimate for compound 3 lay 3.9 percentage points below the measured number, and the stated range covers the measured number.
By their numbers in this assay, from the lowest: compound 1; then compounds 3 and 2 (each within the scatter of the next).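

In this assay the step for methyl in place of hydrogen on a saturated ring carbon, next to the ring nitrogen and next to the ring atom that bears a cyclohexylmethyl group, is a number 1.6 percentage points lower from compound 2 to compound 3 (within the scatter) and gives the series its first reading of a change in one place. Compound 1 and compound 2 differ in more than one place, so they said nothing about this ring carbon, whereas here one added carbon on the six-membered non-aromatic ring with 2 nitrogen leaves the percent remaining within the scatter, for this one pair only. Nothing at hand bears on the reason for this result.

Among these compounds, it stays open whether an ethyl chain, an amine or a carboxylic acid on this same ring carbon would also stay within the scatter of compound 2, since methyl is the only group seen here. Going by these compounds, it also stays open whether methyl at this place would give a similar step with a benzyl group in place of the cyclohexylmethyl group.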